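Swapping the chain-end amine in a farnesyl thioether cysteine amide

The compounds below may be only part of what the source reports. "The series", "measured", "known", "first", "only" and "open" are said of these compounds alone.

Of the compounds shown here, three sharing one core have been measured in a functional assay on MIA PaCa-2 cells (Homo sapiens) for cytotoxicity, read by fluorescence, with a stated time of 48 h; on this read-out higher numbers stand for an effect only at larger amounts of compound and lower numbers for an effect already at smaller amounts. Compound 1 `CC(C)=CCC/C(C)=C/CC/C(C)=C/CSC[C@H](NC(=O)CCCCCN1CCN(C)CC1)C(=O)NC1CC1` gives 10400 nM, compound 2 `CC(C)=CCC/C(C)=C/CC/C(C)=C/CSC[C@H](NC(=O)CCCCCN1CCN(C)CC1)C(=O)N1CCCC1` gives 6000 nM, and compound 3 `CC(C)=CCC/C(C)=C/CC/C(C)=C/CSC[C@H](NC(=O)CCCCCN1CCN(C)CC1)C(=O)NC1CCCC1` gives 10900 nM. Compound 3 lies within the scatter of both neighbours: a 1.0-fold higher number from compound 1 to compound 3 (0.02 log units; within the scatter) and a 1.8-fold higher number from compound 2 to compound 3 (0.26 log units; within the scatter). Compound 4 `CC(C)=CCC/C(C)=C/CC/C(C)=C/CSC[C@H](NC(=O)CCCCCN1CCCC1)C(=O)NC1CCCC1` differs from compound 3 at the far end of the acyl chain: pyrrolidin-1-yl in place of 4-methylpiperazin-1-yl on a saturated chain carbon, five bonds along the chain from a carbonyl carbon. For the measured compounds named here, none of the measured steps touches this position; all three concern the amide side of the core, so they offer no guide to the present change. With nothing pointing either way, compound 4 is expected to stay close to compound 3, an estimated step of a 1.1-fold lower number from compound 3 to compound 4 (0.04 log units; within the scatter) in this assay. Compound 4 is therefore estimated at 10000 nM, within 4000 nM to 25000 nM.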

Compound 4, half-maximal effective concentration: 3200 nM
The estimate for compound 4 lay 3.1-fold (0.49 log units) above the measured number; measured number below the stated range.
By their numbers in this assay, from the lowest: compounds 4, 2, 1 and 3 (each within the scatter of the next, the first and the last beyond it).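

The far end of the acyl chain does affect the read-out in this assay: pyrrolidin-1-yl in place of 4-methylpiperazin-1-yl gives a 3.4-fold lower number from compound 3 to compound 4 (0.53 log units; beyond the scatter) and is the only listed step beyond the scatter, while the three amide-side steps all stayed within it. Nothing available accounts for this step.

The compounds shown leave open whether the step belongs to pyrrolidin-1-yl itself or to the loss of 4-methylpiperazin-1-yl, which piperidin-1-yl or morpholin-4-yl at this place could separate. Also open, on these data alone, is whether the change carries over to the amide groups of compound 1 and compound 2, or to a shorter or longer chain.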